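Series notes: aryl variation on the sulfonamide, dichlorophenyl

The source may report more compounds than this note shows. Statements on the series, on what has been measured and on what is new or still open speak of the compounds shown alone.

Compound 1 `COc1cccc(S(=O)(=O)NC2=NCCN2C(=S)SN2CCn3c2nsc3=S)c1` in a functional assay on KYSE-510 cells (Homo sapiens) for antiproliferative activity, read by crystal violet staining, with a stated time of 96 h (on this read-out higher numbers stand for weaker inhibition of growth and lower numbers for stronger inhibition of growth), gives >= 20000 nM, a limit of the assay.
Compound 2 `O=S(=O)(NC1=NCCN1C(=S)SN1CCn2c1nsc2=S)c1cccc(OC(F)(F)F)c1` gives >= 20000 nM, again a limit.
Compound 3 `O=S(=O)(NC1=NCCN1C(=S)SN1CCn2c1nsc2=S)c1ccc(Br)cc1` gives >= 20000 nM, also a limit.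

Compound 1 thus stands only at the assay limit, as do the other two, and no order among the three can be read. Compound 4 `O=S(=O)(NC1=NCCN1C(=S)SN1CCn2c1nsc2=S)c1ccc(Cl)cc1Cl` differs from compound 1 by 2,4-dichlorophenyl in place of 3-methoxyphenyl on a sulfonyl sulfur. Two measured steps change the same aryl group on the sulfonyl sulfur, a step that the two limits leave unreadable from compound 1 to compound 2 and a step that the two limits leave unreadable from compound 1 to compound 3, and neither has a readable size because of the limit of >= 20000 nM in this assay, at which 3 of the 3 values shown sit. Nothing in the series points to a gain from the new aryl group, so compound 4 is expected to stay at the limit, with an expected step of a number no higher from compound 1 to compound 4 (the limit leaves the size open). For compound 4 the estimate is 20000 nM, between 10000 nM and 40000 nM.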

Compound 4, concentration for 50% growth inhibition: >= 20000 nM
Compound 4 ended at the assay's limit (the forecaster's own chance of this, stated with the estimate: 85%); the middle value lies on the limit itself.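

In this assay no step to compound 4 can be read from compound 1 or compound 3: the limit of >= 20000 nM in this assay, at which 4 of the 4 values shown sit.

The compounds shown leave open which aryl group on the sulfonyl sulfur, if any, gives a value in this assay that is not a limit.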